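Estimating Cytotoxicity for Compound 4

The source may report more compounds than this note shows. Statements on the series, on what has been measured and on what is new or still open speak of the compounds shown alone.

Compound 1 `O=C(COc1cccc2ccccc12)N/N=C/c1ccc(Cl)cc1`: 87.6 ug/mL
Compound 2 `O=C(COc1cccc2ccccc12)N/N=C/c1ccc(O)cc1`: 26.5 ug/mL
Compound 3 `C/C(=N\NC(=O)COc1cccc2ccccc12)c1cccc([N+](=O)[O-])c1`: 12.1 ug/mL

In an ADME assay on MT4 cells (Homo sapiens) for cytotoxicity, read by MTT assay, with a stated time of 4 days (a lower number here means that less compound is tolerated, a higher number that more compound is tolerated), compound 3 gives 12.1 ug/mL, the lowest of the three numbers. Compound 4 `C/C(=N\NC(=O)COc1cccc2ccccc12)c1ccc(C#N)cc1Br` differs from it in one group: 2-bromo-4-cyanophenyl in place of 3-nitrophenyl on a carbon with a double bond to nitrogen. Going by the values given here, no measured step makes this swap. The closest evidence is a 3.3-fold lower number from compound 1 to compound 2 (0.52 log units; beyond the scatter), a different exchange on an aromatic carbon. It shows that one such exchange can move the number modestly, but it sets no direction here. A step beyond the scatter in this assay is therefore not expected. The estimated step is a 1.2-fold higher number from compound 3 to compound 4 (0.09 log units; within the scatter). Compound 4 is estimated at 15 ug/mL, with an expected range of 5 ug/mL to 45 ug/mL.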

Compound 4, half-maximal cytotoxic concentration: 12.1 ug/mL
For compound 4 the middle estimate is 1.2-fold (0.09 log units) above the measured one; low and high end bracket the measured number.
By their numbers in this assay, from the lowest: compounds 3 and 4 (each within the scatter of the next); then compound 2; then compound 1.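

In this assay, putting 2-bromo-4-cyanophenyl in place of 3-nitrophenyl on a carbon with a double bond to nitrogen gives no change at the digits printed from compound 3 to compound 4 (within the scatter) at this position. The earlier step came from a different exchange, so only this one shows that these two substituted phenyl groups can be swapped here without moving the number beyond the scatter. Nothing measured here explains this result.

On these data alone, it remains open whether the bromo or the nitrile alone would give a similar number. An amine or a carboxylic acid on the phenyl ring could also behave differently.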